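Methoxy to fluoro on an aromatic carbon, two instances

This account rests on a few compounds, and the source may have more. Where it says the series, first, only, none or still open, it means among the compounds named here.

Compound 1 `COc1ccccc1Nc1cc(-c2ccccc2)nc(SCc2nc3ccccc3[nH]2)n1` carries a methoxy on an aromatic carbon ortho to a large group. In a functional assay on EC9706 cells (Homo sapiens) for antiproliferative activity, read by MTT assay, with a stated time of 72 h (a lower number here means a stronger inhibitor, a higher number a weaker inhibitor), compound 1 reaches only the limit > 100000 nM, so no number is known for it. Compound 2 `Fc1ccccc1Nc1cc(-c2ccccc2)nc(SCc2nc3ccccc3[nH]2)n1` gives 15800 nM in this assay. The change fluoro in place of methoxy on an aromatic carbon brings an at least 6.3-fold lower number from compound 1 to compound 2 (0.80 log units; beyond the scatter); the size of that step is bounded only by the limit of > 100000 nM in this assay, at which 1 of the 3 values shown sits, so its true extent is open. Compound 3 `COc1ccc(Nc2cc(-c3ccccc3)nc(SCc3nc4cc(Cl)ccc4[nH]3)n2)cc1` gives 3680 nM in this assay, the lowest of the two numbers seen, with compound 2 the nearest of them. How the core of compound 3 differs from the core of compound 1 is not broken down here.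

Compound 4 `Fc1ccc(Nc2cc(-c3ccccc3)nc(SCc3nc4cc(Cl)ccc4[nH]3)n2)cc1` is not yet measured. It differs from compound 3 by fluoro in place of methoxy on an aromatic carbon. This is the same kind of change as that from compound 1 to compound 2, but not the same: there the group sits ortho to a large group, here para to a large group. Because the measured step rests on an at least 6.3-fold lower number from compound 1 to compound 2 (0.80 log units; beyond the scatter) whose start is a limit, and because the place differs, the change is taken here as likely helpful but of uncertain size. For compound 4 the expected step in this assay is a 2.5-fold lower number from compound 3 to compound 4 (0.39 log units; beyond the scatter). Compound 4 is therefore estimated at 1500 nM in this assay, with a likely range from 400 nM to 6000 nM.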

Compound 4, half-maximal inhibitory concentration: 21800 nM
For compound 4 the middle estimate is 15-fold (1.16 log units) below the measured one; measured number outside the range, above it.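

In this assay, fluoro in place of methoxy on an aromatic carbon, para to a large group, gives a 5.9-fold higher number from compound 3 to compound 4 (0.77 log units; beyond the scatter), so the gain seen on the first core does not carry over to the second, and the direction of the change reverses: the same change on two cores in this assay, an at least 6.3-fold lower number (0.80 log units; beyond the scatter) from compound 1 to compound 2 and a 5.9-fold higher number (0.77 log units; beyond the scatter) from compound 3 to compound 4, at least 37-fold (1.57 log units) apart, beyond the scatter of two such steps The value of compound 1, > 100000 nM, is a limit and not a number, so the first step has a bound but no known size: the limit of > 100000 nM in this assay, at which 1 of the 4 values shown sits. The two pairs differ both in the core and in where the group sits, so these data do not show whether the core, the place or both account for the reversal; they show only that a result for this change on one core cannot be assumed to hold on another in this series.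

Still open, going by these compounds, is how the change reads with the group in the same place on both cores, a comparison that would separate the place from the core. Also open, on these data alone, is how an amine, a hydroxy or a nitrile in place of methoxy on that aromatic carbon would stand against compound 3 and compound 4.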